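A methyl group added to compound 3

The source may report more compounds than this note shows. Statements on the series, on what has been measured and on what is new or still open speak of the compounds shown alone.

In a functional assay on MCF7 cells (Homo sapiens) for antiproliferative activity (on this read-out higher numbers stand for weaker inhibition of growth and lower numbers for stronger inhibition of growth), compound 1 (`Cc1cc(-c2nc3ccccc3s2)ccc1N`) gives < 0.1 nM as a limit of the assay and not a number. Compound 2 (`Oc1ccc(-c2nc3ccccc3s2)cc1O`) gives 2190 nM and compound 3 (`COc1ccc(-c2nc3cc(F)ccc3s2)cc1`) gives 490 nM as the lower of the two actual numbers, a gap beyond the scatter. Compound 4 (`COc1ccc(-c2nc3cc(F)ccc3s2)cc1C`) has methyl in place of hydrogen on an aromatic carbon of compound 3, ortho to a methoxy group and meta to a large group (methyl in place of hydrogen on an aromatic carbon). Compound 1 also carries a methyl, differs elsewhere too, and stands at its limit (< 0.1 nM), so a move towards stronger inhibition of growth, beyond the scatter, is expected in this assay for the new compound. The expected change is a 9.8-fold lower number from compound 3 to compound 4 (0.99 log units; beyond the scatter) on this estimate. The estimated value for compound 4 is 50 nM within an expected range of 2 nM to 600 nM in this measurement.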

Compound 4, concentration for 50% growth inhibition: 48 nM
Compound 4: middle estimate off by 1.0-fold (0.02 log units), on the high side; measured number inside the range.
By their numbers in this assay, from the lowest: compound 4; then compound 3; then compound 2. At a limit, below all of these: compound 1.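

In this assay, methyl in place of hydrogen on an aromatic carbon, ortho to a methoxy group and meta to a large group, gives a 10-fold lower number from compound 3 to compound 4 (1.01 log units; beyond the scatter). For the compounds shown here, this is the only step here that differs in one place, so compound 1, compound 2 and compound 3 alone could not show what a single methyl does at this position.

On these data alone, whether an ethyl group, a chlorine or an amine at this position would give a similar step remains open, as does the step for methyl without the methoxy group. Compound 1 also carries a methyl, but its value is a limit and not a number: the limit of < 0.1 nM in this assay, at which 1 of the 4 values shown sits.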